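The source may report more compounds than this note shows. Statements on the series, on what has been measured and on what is new or still open speak of the compounds shown alone.

Compound 1, `COc1ccc2c(OCC[C@@H]3NC(=O)N(C)CCCC/C=C\[C@@H]4C[C@@]4(C(=O)NS(=O)(=O)N(C)C)NC3=O)cc(-c3nc(C(C)C)cs3)nc2c1Cl`: 47800 nM
Compound 2, `COc1ccc2c(OCC[C@@H]3NC(=O)N(C)CCCC/C=C\[C@@H]4C[C@@]4(C(=O)NS(=O)(=O)C4(C)CC4)NC3=O)cc(-c3nc(C(C)C)cs3)nc2c1Cl`: 37400 nM
Compound 3, `COc1ccc2c(OCC[C@@H]3NC(=O)N(C)CCCC/C=C\[C@@H]4C[C@@]4(C(=O)NS(=O)(=O)C4(C#N)CC4)NC3=O)cc(-c3nc(C(C)C)cs3)nc2c1Cl`: > 75000 nM

All three compounds share one core and differ only in the group on a sulfonyl sulfur. In an ADME assay on cells (Homo sapiens) for activation (on this read-out lower numbers stand for higher toxicity in this test and higher numbers for lower toxicity in this test), compound 1 gives 47800 nM and compound 2 gives 37400 nM; the step of a 1.3-fold lower number from compound 1 to compound 2 (0.11 log units; within the scatter) stays within the scatter. For compound 3 the assay reports only a limit, > 75000 nM. Compound 3 thus sits at the limit of > 75000 nM in this assay, at which 1 of the 3 values shown sits, and the steps of an at least 1.5-fold higher number from compound 1 to compound 3 (0.19 log units; that floor lies within the scatter) and an at least 2.0-fold higher number from compound 2 to compound 3 (0.30 log units; that floor lies within the scatter) have floors that lie within the scatter, so no real difference among the three can be claimed.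

Compound 4, `COc1ccc2c(OCC[C@@H]3NC(=O)N(C)CCCC/C=C\[C@@H]4C[C@@]4(C(=O)NS(=O)(=O)N4CCOCC4)NC3=O)cc(-c3nc(C(C)C)cs3)nc2c1Cl`, has not yet been measured. The change from compound 3 is morpholin-4-yl in place of 1-cyanocyclopropyl on a sulfonyl sulfur. The measured steps that bear on it are the ones at the same sulfonyl sulfur, an at least 1.5-fold higher number from compound 1 to compound 3 (0.19 log units; that floor lies within the scatter), an at least 2.0-fold higher number from compound 2 to compound 3 (0.30 log units; that floor lies within the scatter) and a 1.3-fold lower number from compound 1 to compound 2 (0.11 log units; within the scatter), all within the scatter. Compound 1 carries a dimethylamino group at that position, a nitrogen-linked group like the morpholin-4-yl of compound 4. The expected step of an at least 1.3-fold lower number from compound 3 to compound 4 (0.13 log units; that floor lies within the scatter) is therefore small. Compound 4 is estimated at 55000 nM, with a range from 25000 nM to 120000 nM, and a fair chance that only a limit is reported again.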

Compound 4, half-maximal cytotoxic concentration: 26400 nM
For compound 4 the middle estimate is 2.1-fold (0.32 log units) above the measured one, and the stated range covers the measured number.
By their numbers in this assay, from the lowest: compounds 4, 2 and 1 (each within the scatter of the next). At a limit, above all of these: compound 3.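

In this assay, going by these compounds alone, the change on the sulfonyl sulfur gives an at least 2.8-fold lower number from compound 3 to compound 4 (0.45 log units; beyond the scatter), the first step at this position that lies beyond the scatter, and its size is only a floor. Compound 3 gives no exact number here, only a limit of the assay: the limit of > 75000 nM in this assay, at which 1 of the 4 values shown sits. The other two new steps, a 1.4-fold lower number from compound 2 to compound 4 (0.15 log units; within the scatter) and a 1.8-fold lower number from compound 1 to compound 4 (0.26 log units; within the scatter), stay within the scatter, so morpholin-4-yl is set apart from 1-cyanocyclopropyl but not from 1-methylcyclopropyl or dimethylamino.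

The compounds shown leave open how far compound 3 truly stands from compound 1, compound 2 and compound 4, as well as whether the ring oxygen of morpholin-4-yl matters, which a piperidin-1-yl group on the same sulfonyl sulfur would test. They also leave open whether the nitrile of 1-cyanocyclopropyl matters, and a 1-methoxycyclopropyl or 1-fluorocyclopropyl group in that place would give further points of comparison for this group.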